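Ester Side-Chain Changes and Half-Life in Rat Microsomes

A few compounds are considered here, and "the series" means these few. Any claim that something is new, unique, unknown or untested is made for them only; others in the source may bear on it.

Of the compounds shown here, three built on one shared core have been measured in an ADME assay (liver) for pharmacokinetics, with Liver microsome (Rattus norvegicus) as the target, using microsomes; a lower number here means that the compound disappears faster, a higher number that the compound lasts longer. Compound 1 `CCOc1cc(NC(=O)C2(NC(=O)c3ccc4c(C5CCCC5)c(-c5ncc(Cl)cn5)n(C)c4c3)CCC2)ccc1/C=C/C(=O)OCOP(=O)(O)O` carries a phosphate-bearing ester and gives 0.15 h. Compound 2 `CCOC(=O)/C=C/c1ccc(NC(=O)C2(NC(=O)c3ccc4c(C5CCCC5)c(-c5ncc(Cl)cn5)n(C)c4c3)CCC2)cc1OCC`, an ethyl ester, gives 3.07 h, and compound 3 `CCOc1cc(NC(=O)C2(NC(=O)c3ccc4c(C5CCCC5)c(-c5ncc(Cl)cn5)n(C)c4c3)CCC2)ccc1/C=C/C(=O)OCc1ccccc1`, a benzyl ester, gives 2.17 h. Among these three numbers compound 3 stands second highest; its nearest neighbour is compound 2, within the usual scatter of it, while compound 1 lies far below it. The steps of a 20-fold higher number from compound 1 to compound 2 (1.31 log units; beyond the scatter) and a 14-fold higher number from compound 1 to compound 3 (1.16 log units; beyond the scatter) were both large, whereas the step of a 1.4-fold lower number from compound 2 to compound 3 (0.15 log units; within the scatter) stayed within the scatter. Compound 4 `CCOc1cc(NC(=O)C2(NC(=O)c3ccc4c(C5CCCC5)c(-c5ncc(Cl)cn5)n(C)c4c3)CCC2)ccc1/C=C/C(=O)OCCOc1ccccc1` differs from compound 3 by phenoxymethyl in place of phenyl on a saturated chain carbon bound to an oxygen next to a carbonyl group. The step of a 1.4-fold lower number from compound 2 to compound 3 (0.15 log units; within the scatter) also exchanged one group on a saturated chain carbon bound to an oxygen next to a carbonyl group, without any phosphate involved, and so bears most directly on this change; it was small. Compound 4 is therefore expected to show a 1.1-fold lower number from compound 3 to compound 4 (0.04 log units; within the scatter) in this assay, no step beyond the scatter. The estimate for compound 4 is 2 h, expected to fall between 0.9 h and 4.5 h.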

Compound 4, half-life: 16.5 h
Compound 4: middle estimate off by 8.3-fold (0.92 log units), on the low side; the whole stated range lies below it.
By their numbers in this assay, from the lowest: compound 1; then compounds 3 and 2 (each within the scatter of the next); then compound 4.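

In this assay, this position proves able to shift the number even among esters without phosphate: phenoxymethyl in place of phenyl gives a 7.6-fold higher number from compound 3 to compound 4 (0.88 log units; beyond the scatter) and thus a change beyond the scatter. The ethyl ester gives the same message, with a 5.4-fold higher number from compound 2 to compound 4 (0.73 log units; beyond the scatter) on going to the 2-phenoxyethyl ester, and the gap from the phosphate-bearing ester widens to a 110-fold higher number from compound 1 to compound 4 (2.04 log units; beyond the scatter) as the largest step in this set. Compound 3 and compound 4 both carry a six-membered aromatic ring, so that ring alone does not separate them.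

No measurement shown here accounts for the rise. As far as these compounds go, whether the phenoxy oxygen or the longer chain matters stays open, and a 3-phenylpropyl ester, with carbon in place of that oxygen, would separate the two.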